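This account rests on a few compounds, and the source may have more. Where it says the series, first, only, none or still open, it means among the compounds named here.

Working notes on the series. For the measured compounds named here, compound 2 `Fc1cc(-c2nnc3n2N=C(c2ccc(Cl)cc2Cl)CS3)c(Cl)cc1Cl` gives 39200 nM in a functional assay on PC-3 cells (Homo sapiens) for antiproliferative activity, read by sulforhodamine B assay, with a stated time of 48 h (on this read-out higher numbers stand for weaker inhibition of growth and lower numbers for stronger inhibition of growth), and holds the highest of the two numbers so far; its nearest neighbour is compound 1 `Fc1cc(-c2nnc3n2N=C(c2ccc(Cl)cc2)CS3)c(Cl)cc1Cl`, which gives 18700 nM in this assay. Going by the values given here, the single measured step, a 2.1-fold higher number from compound 1 to compound 2 (0.32 log units; beyond the scatter), is chloro in place of hydrogen on an aromatic carbon of the ring attached to the imine carbon.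

Compound 3 `Fc1cc(C2=Nn3c(nnc3-c3cc(F)c(Cl)cc3Cl)SC2)c(Cl)cc1Cl` differs from compound 2 by fluoro in place of hydrogen on an aromatic carbon. Among the compounds with values here, no measured step shows fluoro entering a ring of this core, so the only guide is the modest step of a 2.1-fold higher number from compound 1 to compound 2 (0.32 log units; beyond the scatter), which added a halogen to the same ring and moved the number only slightly beyond the scatter. A step of at most comparable size is expected for compound 3, with the direction uncertain and a small shift toward a higher number taken as the working guess, which gives the expected step of a 1.1-fold higher number from compound 2 to compound 3 (0.06 log units; within the scatter). The estimate for compound 3 in this assay is 45000 nM, with a range from 20000 nM to 100000 nM.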

Compound 3, concentration for 50% growth inhibition: 16900 nM
Beside the measured number, compound 3's estimate is 2.7-fold (0.43 log units) above it; the whole stated range lies above it.
By their numbers in this assay, from the lowest: compounds 3 and 1 (each within the scatter of the next); then compound 2.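

In this assay, fluoro on the 2,4-dichlorophenyl group, ortho to one chloro group and para to the other, gives a 2.3-fold lower number from compound 2 to compound 3 (0.37 log units; beyond the scatter), so a second halogen added to this ring moves the number the opposite way to the chloro of a 2.1-fold higher number from compound 1 to compound 2 (0.32 log units; beyond the scatter). Taken as one change, 2,4-dichloro-5-fluorophenyl in place of 4-chlorophenyl gives a 1.1-fold lower number from compound 1 to compound 3 (0.04 log units; within the scatter), which is within the scatter, so the two added halogens together leave the number where it stood. Nothing available here accounts for this reversal.

Still open, on these data alone, is whether this position tolerates anything other than a halogen, such as an amine, a methoxy group or a carboxylic acid. As far as these compounds go, it is also open whether fluoro gives the same step without the chloro group that compound 2 adds to compound 1.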